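A few compounds are considered here, and "the series" means these few. Any claim that something is new, unique, unknown or untested is made for them only; others in the source may bear on it.

Measured so far in an assay on HT-29 cells for inhibition of Serine-protein kinase ATM (Homo sapiens), read by fluorescence, with a stated time of 1 h; a higher number here means a weaker inhibitor, a lower number a stronger inhibitor:
compound 1, `CCC(CC)CNc1c(C(N)=O)cnc2ccc(-c3cccnc3)cc12`: 73 nM
compound 2, `NC(=O)c1cnc2ccc(-c3cccnc3)cc2c1NC1CCCC1`: 137 nM
compound 3, `CCC(CC)CNc1c(C(N)=O)cnc2ccc(-c3ccc(CO)nc3)cc12`: 87 nM

Compound 1 sits at one end of the three numbers, yet neither companion is separated from it beyond the scatter: the step of a 1.9-fold higher number from compound 1 to compound 2 (0.27 log units; within the scatter) and the step of a 1.2-fold higher number from compound 1 to compound 3 (0.08 log units; within the scatter) are both of the size that repeated measurements produce on their own. The unmeasured compound 4, `CCC(CC)CNc1c(C(N)=O)c(C)nc2ccc(-c3cccnc3)cc12`, differs from compound 1 in one place, (methyl in place of hydrogen on an aromatic carbon). The two measured steps touch other positions of the shared core, the amine substituent in compound 2 and the pyridine substituent in compound 3, and neither changed this assay beyond the scatter. Going by the values given here, no measured pair speaks to the carbon next to the ring nitrogen, so the expectation rests on the general quietness of the series so far. Compound 4 is therefore expected to lie near compound 1, the step of a 1.4-fold higher number from compound 1 to compound 4 (0.14 log units; within the scatter) being an estimate within the scatter. For compound 4 in this assay the estimated value is 100 nM, with a range from 40 nM to 300 nM.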

Compound 4, half-maximal inhibitory concentration: > 30000 nM
Compound 4: only a limit was reported; the forecaster's own chance of this, stated with the estimate: 2%; at least 300-fold (2.47 log units) between middle value and limit.
By their numbers in this assay, from the lowest: compounds 1, 3 and 2 (each within the scatter of the next). At a limit, above all of these: compound 4.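

Methyl in place of hydrogen on this aromatic carbon, next to the ring nitrogen and ortho to a carbamoyl group, is the first change in this assay to reach beyond the scatter (an at least 410-fold higher number from compound 1 to compound 4 (2.61 log units; beyond the scatter)). The earlier steps shown here, at the amine substituent and on the pyridine substituent, showed that those places accept change, but they said nothing about this carbon, which proves far more sensitive to substitution. The value for compound 4 is a limit and not a number: the limit of > 30000 nM in this assay, at which 1 of the 4 values shown sits.

The compounds shown give only hydrogen and methyl at this carbon, so it remains open whether a fluorine, a chlorine, an amine or a hydroxyl would be accepted here. They also leave open why the methyl has so large an effect, and how far the loss extends beyond this limit.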